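The source may hold more compounds than are shown below. What is called first, only, known or untested is meant among the compounds shown, and "the series" means these compounds.

Three compounds share one core and differ at a single position. Compound 1 `CCCCCCCCCCc1ccc(-c2noc([C@H]3CCCN3)n2)cc1` gives 12% in an assay on HeLa cells for inhibition of sphingosine-1-phosphate transporter SPNS2 (Mus musculus), read by LC-MS, tested at 2 uM; on this read-out lower numbers stand for less inhibition and higher numbers for more inhibition at the one concentration tested (going by the name of the read-out). Compound 2 `CCCCCCCCCCc1ccc(-c2noc([C@@H]3CCCN3)n2)cc1` gives 21% in this assay; the step of a number 9 percentage points higher from compound 1 to compound 2 (within the scatter) rests on the fact that compounds 1 and 2 differ only in the configuration as drawn and stays within the scatter. Compound 3 `CCCCCCCCCCc1ccc(-c2noc([C@H](N)CCCCN)n2)cc1` gives 50% in this assay, the highest of the three numbers: the steps of a number 38 percentage points higher from compound 1 to compound 3 (beyond the scatter) and a number 29 percentage points higher from compound 2 to compound 3 (beyond the scatter) both exceed the scatter, and both are the exchange of pyrrolidin-2-yl for 1,5-diaminopentyl on an aromatic carbon.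

Compound 4 `CCCCCCCCCCc1ccc(-c2noc(CC(O)CN(C)C)n2)cc1` has not been measured. The change from compound 3 is 3-(dimethylamino)-2-hydroxypropyl in place of 1,5-diaminopentyl on an aromatic carbon. Among the measured compounds shown here, no measured step covers this exact exchange; the nearest evidence is that the 1,5-diaminopentyl entering gave the two large rises just named, and here it leaves again. A drop beyond the scatter is therefore expected, though the entering group is not the pyrrolidin-2-yl of compounds 1 and 2, so the size is uncertain. The estimated step is a number 25 percentage points lower from compound 3 to compound 4 (beyond the scatter). Compound 4 is expected to give about 25%, most likely between 5% and 48%.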

Compound 4, a percentage reported as inhibition, at one concentration (the size of the read-out at that concentration, not a potency): 61%
The estimate for compound 4 lay 36 percentage points below the measured number, and the stated range ends below it.
By their numbers in this assay, from the lowest: compounds 1 and 2 (each within the scatter of the next); then compound 3; then compound 4.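

The step of a number 11 percentage points higher from compound 3 to compound 4 (beyond the scatter) shows that, in this assay, this position does not depend on the 1,5-diaminopentyl group with its two nitrogens: 3-(dimethylamino)-2-hydroxypropyl, with one nitrogen and one oxygen, reaches a higher number. The steps of a number 40 percentage points higher from compound 2 to compound 4 (beyond the scatter) and a number 49 percentage points higher from compound 1 to compound 4 (beyond the scatter) show that a second open chain, quite different from the first, also stands clearly above both compounds with pyrrolidin-2-yl, so the rise seen with compound 3 is not tied to one particular chain. Nothing given here explains why this exchange raises the number.

As far as these compounds go, what the hydroxyl group and the dimethylamino group each contribute remains open; a 3-(dimethylamino)propyl chain, without the hydroxyl, would separate the two. Also open, from the compounds shown here alone, is whether a longer chain carrying the same two groups would go higher still.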